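Amide side chain change from compound 2 to compound 4

The compounds below may be only part of what the source reports. "The series", "measured", "known", "first", "only" and "open" are said of these compounds alone.

The series keeps a shared core and varies the group on an amide-type nitrogen. It comprises compound 1 (`CCn1c(C(=O)NCCC(=O)OC)ccc1C(CC)(CC)c1ccc(OCS(=O)(=O)c2ccccc2)c(C)c1`), compound 2 (`CCn1c(C(=O)NCCN)ccc1C(CC)(CC)c1ccc(OCS(=O)(=O)c2ccccc2)c(C)c1`), compound 3 (`CCn1c(C(=O)NC2(CO)CC2)ccc1C(CC)(CC)c1ccc(OCS(=O)(=O)c2ccccc2)c(C)c1`) and the unmeasured compound 4 (`CCn1c(C(=O)N[C@H](CO)C(C)C)ccc1C(CC)(CC)c1ccc(OCS(=O)(=O)c2ccccc2)c(C)c1`). In a functional assay on PC-3 cells (Homo sapiens) for antiproliferative activity, read by MTT assay, with a stated time of 24 h (on this read-out higher numbers stand for weaker inhibition and lower numbers for stronger inhibition), compound 1 gives the highest number (40400 nM). Compound 2 reads clearly lower (6890 nM), and compound 3 (3560 nM) lies within the scatter of it.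

In compound 4, 1-(hydroxymethyl)-2-methylpropyl stands in place of 2-aminoethyl on an amide-type nitrogen (1-(hydroxymethyl)-2-methylpropyl in place of 2-aminoethyl on an amide-type nitrogen). The closest measured precedent also replaces 2-aminoethyl with a hydroxymethyl-bearing group, 1-(hydroxymethyl)cyclopropyl, and that step stayed within the scatter (a 1.9-fold lower number from compound 2 to compound 3 (0.29 log units; within the scatter)). The two larger steps both start from the 2-(methoxycarbonyl)ethyl group of compound 1 (a 5.9-fold lower number from compound 1 to compound 2 (0.77 log units; beyond the scatter); an 11-fold lower number from compound 1 to compound 3 (1.05 log units; beyond the scatter)), so they bear less directly on this change. Within the data shown here, three measured compounds give only thin support, and the open-chain branched group of compound 4 has no direct precedent among them.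

In this assay, among the measured compounds shown here, no step clearly beyond the scatter is therefore expected, and the estimated change is small and toward a lower number (a 1.7-fold lower number from compound 2 to compound 4 (0.24 log units; within the scatter)). The estimate for compound 4 is (4000 nM), with an expected range from 1500 nM to 12000 nM in this read-out.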

Compound 4, half-maximal inhibitory concentration: 7300 nM
Beside the measured number, compound 4's estimate is 1.8-fold (0.26 log units) below it; measured number inside the range.
By their numbers in this assay, from the lowest: compounds 3, 2 and 4 (each within the scatter of the next, the first and the last beyond it); then compound 1.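

In this assay, 1-(hydroxymethyl)-2-methylpropyl on the amide-type nitrogen leaves the number level with 2-aminoethyl, at a 1.1-fold higher number from compound 2 to compound 4 (0.03 log units; within the scatter) and this shows that, among the compounds shown, a group with 6 heavy atoms and no nitrogen can match the 3-atom amine chain. The two hydroxymethyl-bearing groups are not interchangeable, since the open-chain group in place of 1-(hydroxymethyl)cyclopropyl gives a 2.1-fold higher number from compound 3 to compound 4 (0.31 log units; beyond the scatter) and this modest step lies just beyond the scatter, although compound 2 stays within the scatter of both. Among these compounds, the new group also joins the other two replacements of 2-(methoxycarbonyl)ethyl in reading lower, with a 5.5-fold lower number from compound 1 to compound 4 (0.74 log units; beyond the scatter) as its step, so compound 1 remains the only compound here with a number this high.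

No measured evidence on the cause of these steps is available. Still open, as far as these compounds go, is whether the methyl ester of compound 1 is itself the liability, which a carboxylic acid at that position would test, and whether a longer chain carrying the hydroxyl, or the opposite configuration at the stereocentre of compound 4, would shift the number in this assay at all.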